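This account rests on a few compounds, and the source may have more. Where it says the series, first, only, none or still open, it means among the compounds named here.

Of the compounds shown here, three sharing one core have been measured in a functional assay on K562 cells (Homo sapiens) for cytotoxicity, read by fluorescence, with a stated time of 72 h; on this read-out lower numbers stand for stronger inhibition and higher numbers for weaker inhibition. Compound 1 `CSc1nc(NCc2ccc(-c3ccccn3)cc2)c2[nH]nc(C(C)C)c2n1`, which carries methylsulfanyl on an aromatic carbon, gives 778 nM. Compound 2 `CC(C)c1n[nH]c2c(NCc3ccc(-c4ccccn4)cc3)nc(N3CCCCC3CCO)nc12`, with 2-(2-hydroxyethyl)piperidin-1-yl there instead, gives 165 nM. Compound 3 `CC(C)c1n[nH]c2c(NCc3ccc(-c4ccccn4)cc3)nc(NCCN)nc12`, with (2-aminoethyl)amino, gives 63 nM, the lowest of the three numbers. The measured steps are a 4.7-fold lower number from compound 1 to compound 2 (0.67 log units; beyond the scatter), which is modest, a 2.6-fold lower number from compound 2 to compound 3 (0.42 log units; beyond the scatter), also modest, and a 12-fold lower number from compound 1 to compound 3 (1.09 log units; beyond the scatter), which is large.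

Compound 4 `CC(C)c1n[nH]c2c(NCc3ccc(-c4ccccn4)cc3)nc(NCc3ccc(-c4ccccn4)cc3)nc12` differs from compound 3 at the end of that side chain: 4-(pyridin-2-yl)phenyl in place of aminomethyl on a saturated chain carbon bound to a nitrogen on an aromatic ring. Thus 4-(pyridin-2-yl)phenyl stands in place of aminomethyl on a saturated chain carbon bound to a nitrogen on an aromatic ring. Among the compounds with values here, no measured compound carries this group at this place, so the three steps bear on the change only indirectly. They do show that compound 3 sits lower than both other compounds, with a 2.6-fold lower number from compound 2 to compound 3 (0.42 log units; beyond the scatter) as its smallest gap. A modest move to a higher number in this assay is therefore expected on leaving its side chain, though with wide uncertainty. The expected step is a 4.0-fold higher number from compound 3 to compound 4 (0.60 log units; beyond the scatter). For compound 4 the estimated value is 250 nM, with an expected range of 60 nM to 1200 nM.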

Compound 4, half-maximal inhibitory concentration: 2540 nM
Compound 4: the middle estimate sits 10-fold (1.01 log units) below what was measured, and the stated range ends below it.
By their numbers in this assay, from the lowest: compound 3; then compound 2; then compound 1; then compound 4.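

In this assay, within the data shown here, every replacement of methylsulfanyl at this place had so far given a lower number, but putting 4-(pyridin-2-yl)phenyl in place of aminomethyl on a saturated chain carbon bound to a nitrogen on an aromatic ring gives a 40-fold higher number from compound 3 to compound 4 (1.61 log units; beyond the scatter), the largest step. The printed values now show that this place does not favour every replacement: compound 1 stands at 778 nM and compound 4 at 2540 nM, the highest number of the four, while compound 2 and compound 3 remain lower than compound 1. The change swaps 2 heavy atoms and no ring for 12 heavy atoms and two aromatic rings, and the hydrogen-bond donor of aminomethyl is lost, but no available evidence bears on what lies behind this rise.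

With all of these differences arriving in a single step, the compounds shown cannot separate the contribution of the added rings from that of the lost amine. From the compounds shown here alone, it remains open how a plain phenyl at the same place, or a longer chain ending in an amine, would read in this assay.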